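The compounds below may be only part of what the source reports. "The series", "measured", "known", "first", "only" and "open" are said of these compounds alone.

Measured so far:
compound 1 `Cc1cc(OCc2ccccc2)c2nc(C)c(C)n2c1`: in a functional assay on the whole organism with Canis familiaris (Canis lupus familiaris) as the target, at a dose of 2 mg/kg by the intravenous route (a lower number here means a weaker effect, a higher number a stronger effect of the compound at the dose given), compound 1 gives 45%.
compound 2 `Cc1nc2c(OCc3ccccc3)cccn2c1N`: in this assay compound 2 gives 97%.

Compound 2 stands highest of the two numbers in this assay; the nearest, compound 1, sits well lower, a gap beyond the scatter. Compound 3 `Cc1cc(OCc2ccccc2)c2nc(C)c(N)n2c1` is compound 2 with a single change: methyl in place of hydrogen on an aromatic carbon. Among the measured compounds shown here, no measured pair carries this change alone, so the size of the step in this assay is not anchored. Compound 1 also bears a methyl and gives the lower number, yet it differs from compound 2 in more than one place, so its value cannot be read as the effect of this change by itself. The reading of compound 2 leaves little room upward, so the step is expected to be a modest drop or none beyond the scatter. For compound 3 in this assay the estimate is 85%, between 60% and 98%, an expected step of a number 12 percentage points lower from compound 2 to compound 3 (beyond the scatter).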

Compound 3, a percentage reported as inhibition, in the whole organism at one dose (the size of the read-out at that dose, not a potency): 46%
Compound 3: the middle estimate sits 39 percentage points above what was measured; the measured number lies below the stated range.
By their numbers in this assay, from the lowest: compounds 1 and 3 (each within the scatter of the next); then compound 2.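

In this assay, among the compounds shown here, methyl in place of hydrogen on an aromatic carbon, two atoms from the ring nitrogen, gives a number 51 percentage points lower from compound 2 to compound 3 (beyond the scatter) and so is the first single change with an anchored size: this position is not indifferent to one added carbon. Amino in place of methyl on an aromatic carbon gives a number 1 percentage points higher from compound 1 to compound 3 (within the scatter) with that ring methyl present, so in this assay the two compounds of this pair cannot be told apart. No measurement on hand explains either step.

Open, going by these compounds, is whether an ethyl group, a methoxy group or a chlorine atom on this carbon would read like the methyl or like the hydrogen. Also open, on these data alone, is how amino in place of methyl reads when this carbon carries hydrogen.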